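This account rests on a few compounds, and the source may have more. Where it says the series, first, only, none or still open, it means among the compounds named here.

Of the compounds shown here, two have so far been measured in a functional assay on M21 cells (Homo sapiens) for antiproliferative activity, read by sulforhodamine B assay, with a stated time of 48 h; a lower number here means a stronger inhibitor, a higher number a weaker inhibitor. Compound 1, `CCCC(=O)Nc1ccc(S(=O)(=O)Oc2ccccc2C(C)C)cc1`, gives 6100 nM and holds the lowest of the two numbers, though its nearest neighbour lies within the scatter. Compound 2, `CCCC(=O)Nc1ccc(S(=O)(=O)Oc2ccccc2I)cc1`, gives 9000 nM. Going by the values given here, the only measured step, a 1.5-fold higher number from compound 1 to compound 2 (0.17 log units; within the scatter), puts iodo in place of isopropyl on an aromatic carbon.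

Compound 3, `CC(C)c1ccccc1OS(=O)(=O)c1ccc(NC(=O)CCl)cc1`, has not been measured. It differs from compound 1 by chloro in place of ethyl on a saturated chain carbon bound to a carbonyl carbon. Among the compounds with values here, the one measured step concerns an aromatic carbon, not the saturated chain carbon bound to a carbonyl carbon, so it does not bear on this change, and nothing among the measured compounds shows what exchanging ethyl for chloro at that place does in this assay. Within the data shown here, with no comparable step, the expectation is a step of no particular direction and none beyond the scatter, with a wide range to reflect the lack of evidence. Compound 3 is therefore estimated at 6100 nM, with a range from 2000 nM to 18000 nM. The expected step of no change at the digits printed from compound 1 to compound 3 (within the scatter) amounts to essentially none.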

Compound 3, half-maximal inhibitory concentration: 3900 nM
For compound 3 the middle estimate is 1.6-fold (0.19 log units) above the measured one; low and high end bracket the measured number.
By their numbers in this assay, from the lowest: compounds 3, 1 and 2 (each within the scatter of the next, the first and the last beyond it).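

In this assay, going by these compounds alone, the exchange of propyl for chloromethyl on the carbonyl of the amide gives a 1.6-fold lower number from compound 1 to compound 3 (0.19 log units; within the scatter), the first reading at this place. The result shows that, in this assay, this change on a saturated chain carbon bound to a carbonyl carbon does not separate the two compounds beyond the scatter, so the data give no sign that ethyl and chloro differ here, and the side of the molecule carrying this chain now has a measured step of its own alongside the earlier one on an aromatic carbon. Nothing available accounts for the size of this step or says how the chloro group acts at this place.

The compounds shown leave open whether a longer chain, an amine or a carboxylic acid at this same carbon would move the number beyond the scatter, since one exchange cannot show how far this place can be varied. They also leave open whether chloro in place of ethyl gives a similar step when iodo replaces isopropyl on the aromatic carbon, as in compound 2.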